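This account rests on a few compounds, and the source may have more. Where it says the series, first, only, none or still open, it means among the compounds named here.

Compound 2 `Cc1nc(-c2ccccc2)c(C(=O)N2CCN(c3cccc(C)c3C)CC2)o1` is one of three compounds tested in a functional assay on HL-60 cells (Homo sapiens) for inhibition, read by MTT assay, with a stated time of 72 h; a lower number here means a stronger inhibitor, a higher number a weaker inhibitor. In this assay compound 2 gives 35 nM, the highest of the two numbers reported. The nearest is compound 1 `COc1cc(OC)cc(N2CCN(C(=O)c3oc(C)nc3-c3cccc(F)c3)CC2)c1`, which gives 28.2 nM; the two values lie within the scatter of each other, so no order between them can be read. The third compound, compound 3 `Cc1nc(-c2ccc(F)cc2)c(C(=O)N2CCN(c3ccc(Cl)cc3)CC2)o1`, is reported in this assay as "not active" (no number reported), without a number.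

Compound 4 `COc1cc(OC)cc(N2CCN(C(=O)c3oc(C)nc3-c3ccccc3)CC2)c1` has not yet been measured. It differs from compound 2 in a single place: 3,5-dimethoxyphenyl in place of 2,3-dimethylphenyl on an amine nitrogen in a ring. Among the compounds with values here, no step between measured compounds is available to show what this change does on its own. The 3,5-dimethoxyphenyl on an amine nitrogen in a ring does, however, occur in compound 1, which gives 28.2 nM in this assay, a value within the scatter of that of compound 2.

On that basis the step of a 1.2-fold lower number from compound 2 to compound 4 (0.07 log units; within the scatter) is expected to be small, in either direction or none beyond the scatter. Compound 4 is therefore estimated to give about 30 nM in this assay, with a plausible range from 12 nM to 75 nM.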

Compound 4, half-maximal inhibitory concentration: 19.2 nM
Compound 4: middle estimate off by 1.6-fold (0.19 log units), on the high side, within the range that was stated.
By their numbers in this assay, from the lowest: compounds 4, 1 and 2 (each within the scatter of the next).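

In this assay, the replacement on an amine nitrogen in a ring can now be read directly, as a measured pair rather than by inference from compound 1: 3,5-dimethoxyphenyl in place of 2,3-dimethylphenyl gives a 1.8-fold lower number from compound 2 to compound 4 (0.26 log units; within the scatter), so the two groups cannot be told apart at this position, even though the entering group carries two hydrogen-bond acceptors and the leaving group none. Within the data shown here, the pair sharing the 3,5-dimethoxyphenyl also isolates a second place for the first time: hydrogen in place of fluoro on an aromatic carbon gives a 1.5-fold lower number from compound 1 to compound 4 (0.17 log units; within the scatter), so this change likewise shows no effect that can be separated from the scatter. No measurement here offers an explanation for either step.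

From the compounds shown here alone, both steps cover only aromatic groups and a single small exchange, so it stays open how the number would respond to a longer chain on the ring nitrogen, or to an amine or a carboxylic acid on the aromatic ring. Compound 3 differs from every numbered compound in more than one place, so its "not active" report cannot be tied to any single change.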